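Swapping the ring pair on the amide carbonyl of compound 2

The compounds below may be only part of what the source reports. "The series", "measured", "known", "first", "only" and "open" are said of these compounds alone.

Two compounds share an amide linked through a methylene to a benzene ring bearing a sulfonyl group. Compound 1 `Cc1ccccc1S(=O)(=O)c1ccc(CNC(=O)c2cc3cnccc3[nH]2)cc1` carries one fused ring pair on the carbonyl; in an ADME assay on microsomes from liver (Mus musculus) for metabolic stability, read by LC-MS, with a stated time of 30 min, tested at 1 uM (on this read-out lower numbers stand for a less stable compound and higher numbers for a more stable compound), compound 1 gives 15%. Compound 2 `O=C(NCc1ccc(S(=O)(=O)c2ccccc2)cc1)c1cc2ncccc2s1` carries a different fused ring pair there; in this assay compound 2 gives 1.6%, the lowest of the two numbers, and the gap to compound 1 is beyond the usual scatter of this assay.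

Compound 3 `O=C(NCc1ccc(S(=O)(=O)c2ccccc2)cc1)c1cnc2nccn2c1` has not yet been measured. It differs from compound 2 in one place: a group of 9 heavy atoms (6 carbon, 3 nitrogen; one five-membered aromatic ring with 2 hetero atoms, one six-membered aromatic ring with 2 hetero atoms) in place of a group of 9 heavy atoms (7 carbon, 1 nitrogen, 1 sulfur; one five-membered aromatic ring with 1 hetero atom, one six-membered aromatic ring with 1 hetero atom), on a carbonyl carbon. Going by the values given here, no measured pair of compounds shares exactly this change, so there is no directly comparable step to lean on. Since compound 2 sits near the bottom of what this assay can read, the step from compound 2 to compound 3 is expected to be upward, and of a modest size, a number 8.4 percentage points higher from compound 2 to compound 3 (within the scatter). For compound 3 in this assay, the expected value is 10%, with a plausible range from 1% to 40%.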

Compound 3, percent of the compound remaining: 30%
Estimate against measurement, compound 3: 20 percentage points below, within the range that was stated.
By their numbers in this assay, from the lowest: compound 2; then compound 1; then compound 3.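

The ring pair on the carbonyl carbon matters for this read-out. With the rest of the molecule unchanged, putting the group of 6 carbon and 3 nitrogen atoms in place of the group of 7 carbon, 1 nitrogen and 1 sulfur atoms moves the result in this assay by a number 28.4 percentage points higher from compound 2 to compound 3 (beyond the scatter) and lifts the series clear of the bottom of the assay's range. Going by these compounds alone, this is the first comparison here in which only one place differs, so the shift can be tied to this swap alone, although nothing measured here explains why the number moves.

A single pair cannot separate the loss of the sulfur from the gain in ring nitrogens or from the different arrangement of the two fused rings. Also open, on these data alone, is how the number would respond to a methyl group or a fluorine on the entering ring pair, to a single pyridine ring on the carbonyl carbon, or to the same swap made on a compound with other groups elsewhere.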